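Trimming two methyl groups from an aminoalkoxy chain

This account rests on a few compounds, and the source may have more. Where it says the series, first, only, none or still open, it means among the compounds named here.

Compound 1 `CC(C)(O)CN1CCC(Oc2ccc([C@H]3CC[C@]4(CC3)OOC3(O4)C4CC5CC(C4)CC3C5)cc2)CC1` and compound 2 `CC(C)(N)CCOc1ccc([C@H]2CC[C@]3(CC2)OOC2(O3)C3CC4CC(C3)CC2C4)cc1` share one core and differ only in the chain on the aromatic oxygen. In an ADME assay on microsomes from liver (Homo sapiens) for metabolic stability, read by LC-MS, tested at 1 uM (a lower number here means slower removal, a higher number faster removal of the compound), compound 1 gives 18 mL.min-1.g-1. Going by these compounds, for compound 2 this assay reports only a limit, < 7 mL.min-1.g-1, so its true number is unknown; this is the limit of < 7 mL.min-1.g-1 in this assay, at which 1 of the 2 values shown sits. For the measured compounds named here, the single measured step, an at least 2.5-fold lower number from compound 1 to compound 2 (0.41 log units; beyond the scatter), exchanges the whole oxygen-bound group and therefore does not speak directly to a smaller trimming of the chain. Compound 3 `NCCCCOc1ccc([C@H]2CC[C@]3(CC2)OOC2(O3)C3CC4CC(C3)CC2C4)cc1` is compound 2 with 2-aminoethyl in place of 1-amino-1-methylethyl on a saturated chain carbon, two bonds along the chain from an oxygen on an aromatic ring. Going by the values given here, no measured step covers this change, so the expected step is small, a number no lower from compound 2 to compound 3 (the limit leaves the size open), because compound 2 already sits at the limit < 7 mL.min-1.g-1. Compound 3 is estimated at 7 mL.min-1.g-1, between 3 mL.min-1.g-1 and 18 mL.min-1.g-1, and this assay may well again return only a limit for it.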

Compound 3, intrinsic clearance in microsomes: < 7 mL.min-1.g-1
Compound 3: no number, only a limit; the forecaster's own chance of this, stated with the estimate: 50%; the middle value lies on the limit itself.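

In this assay, compound 3 returns only a limit, < 7 mL.min-1.g-1, not a number. Putting 4-aminobutyl in place of 1-(2-hydroxy-2-methylpropyl)piperidin-4-yl on the aromatic oxygen gives an at least 2.5-fold lower number from compound 1 to compound 3 (0.41 log units; beyond the scatter), so 3-amino-3-methylbutyl is not the only amine chain at this position to give a step of this kind. The step from compound 2 to compound 3 cannot be read, because both values are limits: the limit of < 7 mL.min-1.g-1 in this assay, at which 2 of the 3 values shown sit.

Going by these compounds, whether the change from 1-amino-1-methylethyl to 2-aminoethyl alters the clearance at all therefore stays unknown. Also open, on these data alone, is whether a shorter chain such as 3-aminopropyl, or a carboxylic acid in place of the amine at the end of the chain, would still stay at this limit.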